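The source may report more compounds than this note shows. Statements on the series, on what has been measured and on what is new or still open speak of the compounds shown alone.

Compound 2, `CCCCCN(CCCCC)C(=O)N1CCN(C(=O)N(c2ccccc2)c2ccccc2)[C@H](C(=O)NCCNC(C)=O)C1`: 140 nM. Compound 1, `CCCCCN(CCCCC)C(=O)N1CCN(C(=O)N(c2ccccc2)c2ccccc2)[C@H](C(=O)NCC(=O)O)C1`: 597 nM.

Compound 2 gives the lowest of the two numbers in an assay on CHO cells for binding affinity to Substance-P receptor (Homo sapiens); on this read-out lower numbers stand for stronger inhibition and higher numbers for weaker inhibition; compound 1 sits a step away, a 4.3-fold lower number from compound 1 to compound 2 (0.63 log units; beyond the scatter). Compound 3, `CCCCCN(CCCCC)C(=O)N1CCN(C(=O)N(c2ccccc2)c2ccccc2)[C@H](C(=O)NCCN(C)C)C1`, differs from compound 2 by dimethylamino in place of acetamido on a saturated chain carbon, two bonds along the chain from an amide-type nitrogen. Among the compounds with values here, no measured step covers this exchange; the one step known, from compound 1 to compound 2, concerns a different pair of groups on the same chain and only shows that replacement there can shift this assay beyond the scatter. Compound 3 is therefore expected to stay near compound 2, a 1.4-fold lower number from compound 2 to compound 3 (0.15 log units; within the scatter), estimated at 100 nM with a range of 30 nM to 400 nM.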

Compound 3, half-maximal inhibitory concentration: 55 nM
Compound 3: middle estimate off by 1.8-fold (0.26 log units), on the high side; the range from low to high includes it.
By their numbers in this assay, from the lowest: compound 3; then compound 2; then compound 1.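

Replacing acetamido with dimethylamino on this chain gives a 2.5-fold lower number from compound 2 to compound 3 (0.41 log units; beyond the scatter) in this assay, so this place still responds to change when the carboxy group is absent from both compounds. Against the carboxy compound, (dimethylamino)methyl gives an 11-fold lower number from compound 1 to compound 3 (1.04 log units; beyond the scatter) and is the largest step seen here so far. No evidence at hand bears on the reason for either step.

The compounds shown leave open whether a diethylamino group or an unsubstituted amine would follow dimethylamino in this assay. They also leave open how a longer chain carrying dimethylamino would compare with 2-(dimethylamino)ethyl.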